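The source may hold more compounds than are shown below. What is called first, only, known or untested is meant among the compounds shown, and "the series" means these compounds.

Compound 1 `CN(O)C(=O)c1cc2ccn(Cc3ccc(F)cc3)c2cn1` was measured in an ADME assay on CEM-SS cells (Homo sapiens) for cytotoxicity, read by XTT assay (on this read-out higher numbers stand for lower toxicity in this test and lower numbers for higher toxicity in this test), where compound 1 gives 135000 nM. Within the data shown here, only one other compound shares this read-out: compound 2 `CN(O)C(=O)c1cc2ccn(Cc3ccc(F)cc3F)c2cn1`, which in this assay gives 200000 nM. Among the measured compounds shown here, the single measured step, a 1.5-fold higher number from compound 1 to compound 2 (0.17 log units; within the scatter), comes from a fluoro in place of hydrogen on an aromatic carbon, so compound 1 stands beside compound 2 with nothing to separate the two numbers beyond repeat-to-repeat noise. The unmeasured compound 3 `CN(O)C(=O)c1cc2c(CO)cn(Cc3ccc(F)cc3)c2cn1` differs from compound 1 at another place: hydroxymethyl in place of hydrogen on an aromatic carbon. For the measured compounds named here, no measured step touches this part of the shared core, and the only step in hand, a 1.5-fold higher number from compound 1 to compound 2 (0.17 log units; within the scatter), concerns a different change and was itself within the scatter. The footing for a forecast is thus thin. Compound 3 is expected to sit close to compound 1, with a step of a 1.1-fold higher number from compound 1 to compound 3 (0.05 log units; within the scatter) that need not exceed the scatter in either direction. The estimate for compound 3 in this assay is 150000 nM, within a range from 70000 nM to 320000 nM.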

Compound 3, half-maximal cytotoxic concentration: > 266000 nM
Compound 3 was reported as a limit (the forecaster's own chance of this, stated with the estimate: 25%); middle value at least 1.7-fold (0.24 log units) away from the limit.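

Among these compounds, this is the first reading for any change at this part of the shared core: with hydroxymethyl in place of hydrogen, on an aromatic carbon of the five-membered aromatic ring, two ring bonds from the ring nitrogen, this assay shows an at least 1.9-fold higher number from compound 1 to compound 3 (0.29 log units; that floor lies within the scatter). The value of compound 3 is a limit and not a number, the only one of its kind among the compounds shown: the limit of > 266000 nM in this assay, at which 1 of the 3 values shown sits. The result therefore shows that this carbon can carry hydroxymethyl without any sign of higher toxicity in this test, although the printed floor of the step does not by itself set compound 3 apart from compound 1 beyond the scatter.

On these data alone, how far the true value of compound 3 lies from that of compound 1 remains open, and so does whether the second fluoro of compound 2 would read the same way with hydroxymethyl present. Also open, as far as these compounds go, is how an amine, a carboxylic acid or a longer chain on this same aromatic carbon would read in this assay, and whether any such group would bring the number down.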